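Moving the fluorine on the benzyl arm

A few compounds are considered here, and "the series" means these few. Any claim that something is new, unique, unknown or untested is made for them only; others in the source may bear on it.

Of the compounds shown here, three built on one shared core have been tested in a functional assay on MDA-MB-231 cells (Homo sapiens) for cytotoxicity, read by MTT assay, with a stated time of 24 h; a higher number here means a weaker inhibitor, a lower number a stronger inhibitor. Compound 1 `COc1ccc(/C=C2\CN(C(=S)SCc3cn(Cc4ccccc4Cl)nn3)C/C(=C\c3ccc(OC)cc3)C2=O)cc1` reaches only the limit of this assay, recorded as > 100000 nM; this is the limit (the limit of > 100000 nM in this assay, at which 1 of the 3 values shown sits). Compound 2 `Cc1ccc(/C=C2\CN(C(=S)SCc3cn(Cc4ccccc4F)nn3)C/C(=C\c3ccc(C)cc3)C2=O)cc1` gives 91500 nM. Compound 3 `Cc1ccc(/C=C2\CN(Cc3cn(Cc4cccc(Cl)c4)nn3)C/C(=C\c3ccc(C)cc3)C2=O)cc1` gives 9000 nM. Of the two numbers that are not limits, compound 2 stands highest, and compound 3 sits a clear step lower, a gap beyond the scatter of repeated measurements.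

Compound 4 `Cc1ccc(/C=C2\CN(C(=S)SCc3cn(Cc4ccc(F)cc4)nn3)C/C(=C\c3ccc(C)cc3)C2=O)cc1` has not yet been measured. It differs from compound 2 in one place: 4-fluorophenyl in place of 2-fluorophenyl on a saturated chain carbon bound to an aromatic nitrogen. For the measured compounds named here, no pair of measured compounds shows a change of this kind, so there is no measured step to lean on. The expected step of a 1.0-fold lower number from compound 2 to compound 4 (0.01 log units; within the scatter) is small enough to fall within the usual scatter, in no firm direction. Compound 4 is therefore estimated at 90000 nM, with a range from 30000 nM to 270000 nM, and a real chance that this assay reports only a limit.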

Compound 4, half-maximal inhibitory concentration: 45600 nM
Compound 4: the middle estimate sits 2.0-fold (0.30 log units) above what was measured; the measured number falls inside the stated range.
By their numbers in this assay, from the lowest: compound 3; then compounds 4 and 2 (each within the scatter of the next). At a limit, above all of these: compound 1.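

Moving the fluorine from 2-fluorophenyl to 4-fluorophenyl, on a saturated chain carbon bound to an aromatic nitrogen, gives the first direct reading of a change at this position. In this assay that reading is a 2.0-fold lower number from compound 2 to compound 4 (0.30 log units; within the scatter). The two placements of the fluorine therefore cannot be told apart in this assay, and nothing measured here accounts for the step.

The compounds shown leave open whether a different group in place of the fluorine on this phenyl ring, such as an amine or a carboxylic acid, would move the number beyond the scatter. They also leave open whether the same shift of a chlorine atom, rather than a fluorine atom, would prove just as small.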